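Adding to the ring group of compound 2

The source may hold more compounds than are shown below. What is called first, only, known or untested is meant among the compounds shown, and "the series" means these compounds.

Measured in a functional assay (blood) for inhibition, with Homo sapiens as the target; on this read-out higher numbers stand for weaker inhibition and lower numbers for stronger inhibition:
- compound 1 `N#Cc1cc(-c2ccoc2)c2ccc(OCc3cccc(C4(O)CCOCC4)c3)cc2c1`: 10 nM
- compound 2 `OC1(c2cccc(COc3ccc4c(-c5ccoc5)cc(C5=NCCO5)cc4c3)c2)CCOCC1`: 50 nM

Compound 2 stands at the higher of the two numbers, at 50 nM, and so shows the weaker inhibition. Compound 3 `CC1(C)COC(c2cc(-c3ccoc3)c3ccc(OCc4cccc(C5(O)CCOCC5)c4)cc3c2)=N1` keeps the core of compound 2 and differs in one place: a group of 7 heavy atoms (5 carbon, 1 nitrogen, 1 oxygen; one five-membered non-aromatic ring with 2 hetero atoms) in place of a group of 5 heavy atoms (3 carbon, 1 nitrogen, 1 oxygen; one five-membered non-aromatic ring with 2 hetero atoms), on an aromatic carbon. Among the measured compounds shown here, only one measured step bears on this change, and only loosely: a 5.0-fold higher number from compound 1 to compound 2 (0.70 log units; beyond the scatter). That step is modest but beyond the scatter, and it replaced a group at this same aromatic carbon. For the measured compounds named here, no measured pair tests a change within the five-membered ring group itself. In this assay, no step beyond the scatter is therefore expected, with a slight lean towards a higher number. The expected step is a 1.4-fold higher number from compound 2 to compound 3 (0.15 log units; within the scatter). Compound 3 is estimated at 70 nM, with an expected range of 22 nM to 220 nM.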

Compound 3, half-maximal inhibitory concentration: 2900 nM
Compound 3: the middle estimate sits 41-fold (1.62 log units) below what was measured; the measured number lies above the stated range.
By their numbers in this assay, from the lowest: compound 1; then compound 2; then compound 3.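

In this assay, among the compounds shown here, the ring group at this aromatic carbon proves far more sensitive to change than the earlier compounds suggested: the group of 7 heavy atoms in place of the group of 5 heavy atoms gives a 58-fold higher number from compound 2 to compound 3 (1.76 log units; beyond the scatter) and so costs more than the first replacement did. Set against the nitrile, the same group gives a 290-fold higher number from compound 1 to compound 3 (2.46 log units; beyond the scatter) and stands as the poorest of the three replacements at this position. Still open, on these data alone, is whether a single methyl group on the five-membered ring would carry a smaller step than the larger group does. Also open, as far as these compounds go, is whether a group of another kind at this aromatic carbon, such as a primary amide or an amine, would match the nitrile of compound 1. No measurement at hand speaks to the reason for this large step.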